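The source may hold more compounds than are shown below. What is called first, only, known or untested is meant among the compounds shown, and "the series" means these compounds.

Measured so far in the series:
compound 1, `CCCCCCCCCCCCCCNC(=O)[C@@H](NC(=O)c1ccccc1)[C@@H](C)O`: 118000 nM
compound 2, `CCCCCCCCCCCCCCNC(=O)[C@@H](NC(=O)c1ccco1)[C@@H](C)O`: 190000 nM
compound 3, `CCCCCCCCCCCCCCCCCCNC(=O)[C@@H](NC(=O)c1ccccc1)[C@@H](C)O`: 113000 nM

All three were run in a functional assay on A-431 cells (Homo sapiens) for cytotoxicity, read by MTT assay, with a stated time of 48 h; on this read-out lower numbers stand for stronger inhibition and higher numbers for weaker inhibition. Compound 1 and compound 2 differ by furan-2-yl in place of phenyl on a carbonyl carbon; the step is a 1.6-fold higher number from compound 1 to compound 2 (0.21 log units; within the scatter). The core of compound 3 differs from the core of compound 1 by butyl in place of hydrogen on a saturated chain carbon, ten or more bonds along the chain from an amide-type nitrogen, and that step is a 1.0-fold lower number from compound 1 to compound 3 (0.02 log units; within the scatter). Neither step leaves the scatter, so no ordering among the three is claimed.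

Compound 4, `CCCCCCCCCCCCCCCCCCNC(=O)[C@@H](NC(=O)c1ccco1)[C@@H](C)O`, is not yet measured in this assay. It differs from compound 3 by furan-2-yl in place of phenyl on a carbonyl carbon, the same change as from compound 1 to compound 2, made here on the longer core. The place of the change is the same in both pairs. The step from compound 3 to compound 4 is expected to be a 1.6-fold higher number from compound 3 to compound 4 (0.20 log units; within the scatter), essentially a repeat of a 1.6-fold higher number from compound 1 to compound 2 (0.21 log units; within the scatter), since the chain lengthening gave only a 1.0-fold lower number from compound 1 to compound 3 (0.02 log units; within the scatter) and nothing in the data suggests the two changes interact. Compound 4 is therefore estimated at 180000 nM, expected to fall between 100000 nM and 330000 nM.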

Compound 4, half-maximal inhibitory concentration: 19900 nM
Estimate against measurement, compound 4: 9.0-fold (0.96 log units) above; measured number outside the range, below it.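

In this assay, furan-2-yl in place of phenyl on the carbonyl carbon gives a 5.7-fold lower number from compound 3 to compound 4 (0.75 log units; beyond the scatter), so the step seen on the shorter core does not carry over to the longer one: the same change on two cores in this assay, a 1.6-fold higher number (0.21 log units; within the scatter) from compound 1 to compound 2 and a 5.7-fold lower number (0.75 log units; beyond the scatter) from compound 3 to compound 4, 9.1-fold (0.96 log units) apart, beyond the scatter of two such steps. Read the other way, the chain lengthening gives a 9.5-fold lower number from compound 2 to compound 4 (0.98 log units; beyond the scatter) with furan-2-yl in place, so its step also depends on the group on the carbonyl carbon: the same change on two cores in this assay, a 1.0-fold lower number (0.02 log units; within the scatter) from compound 1 to compound 3 and a 9.5-fold lower number (0.98 log units; beyond the scatter) from compound 2 to compound 4, 9.1-fold (0.96 log units) apart, beyond the scatter of two such steps. Within the data shown here, the two changes are therefore not additive across these four compounds, but this rests on a single set of four and on the one value of compound 4, and it shows neither what underlies the interaction nor whether it extends to any other core.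

Going by these compounds, it remains open whether the shift in compound 4 appears only at this chain length or also with a chain of intermediate length or a longer chain. Also open, on these data alone, is whether another group on the carbonyl carbon, such as thiophen-2-yl, would behave as furan-2-yl does on the longer core.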